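Swapping the amide side chain: compound 1 to compound 3

A few compounds are considered here, and "the series" means these few. Any claim that something is new, unique, unknown or untested is made for them only; others in the source may bear on it.

Going by the values given here, in a functional assay on MCF7 cells (Homo sapiens) for antiproliferative activity, read by MTT assay, with a stated time of 24 h (on this read-out higher numbers stand for weaker inhibition and lower numbers for stronger inhibition), compound 1 `CCN(CC)CCNC(=O)c1ccc(C(CC)(CC)c2ccc(OCS(=O)(=O)c3ccccc3)c(C)c2)n1CC` gives 4680 nM, the lowest of the two numbers known. Compound 2 `CCn1c(C(=O)N[C@@H](CO)CCO)ccc1C(CC)(CC)c1ccc(OCS(=O)(=O)c2ccccc2)c(C)c1` gives 27400 nM in this assay, and the step of a 5.9-fold higher number from compound 1 to compound 2 (0.77 log units; beyond the scatter) is the only one recorded. Compound 3 `CCn1c(C(=O)N[C@H](CO)CCCO)ccc1C(CC)(CC)c1ccc(OCS(=O)(=O)c2ccccc2)c(C)c1` differs from compound 1 in a similar way: a group of 7 heavy atoms (5 carbon, 2 oxygen; no ring) in place of a group of 7 heavy atoms (6 carbon, 1 nitrogen; no ring), on an amide-type nitrogen. Since the step from compound 1 to compound 2 was sizeable, a comparable weakening is expected here, giving a 5.1-fold higher number from compound 1 to compound 3 (0.71 log units; beyond the scatter). Compound 3 is therefore estimated at 24000 nM in this assay, likely between 9000 nM and 65000 nM.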

Compound 3, half-maximal inhibitory concentration: 31400 nM
The estimate for compound 3 lay 1.3-fold (0.12 log units) below the measured number; low and high end bracket the measured number.
By their numbers in this assay, from the lowest: compound 1; then compounds 2 and 3 (each within the scatter of the next).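

Replacing 2-(diethylamino)ethyl with a second hydroxyl-bearing chain on the amide-type nitrogen again gives weaker inhibition in this assay (a 6.7-fold higher number from compound 1 to compound 3 (0.83 log units; beyond the scatter)), so the loss seen with compound 2 is not confined to a single chain. The two hydroxyl-bearing chains cannot be told apart here (a 1.1-fold higher number from compound 2 to compound 3 (0.06 log units; within the scatter)). No measured evidence accounts for the loss. Still open, going by these compounds, is whether the amine nitrogen itself matters. A plain hexyl chain, a dimethylamino chain or a carboxylic acid chain on this nitrogen would help to settle that.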